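A few compounds are considered here, and "the series" means these few. Any claim that something is new, unique, unknown or untested is made for them only; others in the source may bear on it.

Compound 1 `CC(C)[C@H](NC(=O)[C@]1(Cc2ccccc2)CCN1C(=O)OCc1ccccc1)C(N)=O` in an ADME assay on HELF cells (Homo sapiens) for cytotoxicity, with a stated time of 3 days (a lower number here means that less compound is tolerated, a higher number that more compound is tolerated), gives > 100000 nM, a limit of this assay rather than a number.
Compound 2 `C[C@H](NC(=O)[C@]1(Cc2ccccc2)CCN1C(=O)Oc1cccc2ccccc12)C(N)=O` gives > 100000 nM, again a limit.
Compound 3 `CC(C)[C@H](NC(=O)[C@@]1(Cc2ccccc2)CCN1C(=O)OCc1ccccc1)C(N)=O` gives > 100000 nM, also a limit.

Compound 1 thus stands at the limit, and so do the two other measured compounds (the limit of > 100000 nM in this assay, at which 3 of the 3 values shown sit). Compound 1 and compound 3 share every atom and bond and differ only in configuration as drawn (the fact that compounds 1 and 3 differ only in the configuration as drawn), yet the step that the two limits leave unreadable from compound 1 to compound 3 cannot be read because the limit of > 100000 nM in this assay, at which 3 of the 3 values shown sit, sits on both ends. Within the data shown here, compound 2 carries a different ester part and a different side chain from compound 1, and no single step joins the two; their values show only that both lie at the limit.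

Compound 4 `C[C@H](NC(=O)[C@]1(Cc2ccccc2)CCN1C(=O)OCc1ccccc1)C(=O)N(C)C` is the next one. Relative to compound 1 the change is 1-(dimethylcarbamoyl)ethyl in place of 1-carbamoyl-2-methylpropyl on an amide-type nitrogen. Among the measured compounds shown here, no measured step bears directly on this change, and none of the measured steps has a readable size; all three values sit at the limit (the limit of > 100000 nM in this assay, at which 3 of the 3 values shown sit). On that footing the step of a number no higher from compound 1 to compound 4 (the limit leaves the size open) is expected to be none beyond the scatter, with compound 4 most likely reported as a limit as well. The estimate for compound 4 in this assay is 100000 nM, in a range from 50000 nM to 300000 nM.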

Compound 4, minimum cytotoxic concentration: > 100000 nM
Compound 4 gave a limit, no number (the forecaster's own chance of this, stated with the estimate: 85%); the middle value sits exactly at the limit.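

Compound 4, like compound 1, gives only a limit, so no size can be read for the step between them in this assay: the limit of > 100000 nM in this assay, at which 4 of the 4 values shown sit.

The compounds shown leave open whether any change among them, in configuration or in the group on the amide-type nitrogen, alters the minimum cytotoxic concentration in this assay at all.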